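The source may hold more compounds than are shown below. What is called first, only, known or untested is meant among the compounds shown, and "the series" means these compounds.

Measured so far in a functional assay on HeLa cells (Homo sapiens) for cytotoxicity, read by MTT assay, with a stated time of 48 h; a lower number here means a stronger inhibitor, a higher number a weaker inhibitor:
- compound 1 `O=C(O)CN1C(=O)/C(=C/c2nc3ccccc3n2Cc2ccc(Br)cc2F)SC1=S`: > 50000 nM (a limit)
- compound 2 `N#Cc1ccc(Cn2c(/C=C3\SC(=S)N(CC(=O)O)C3=O)nc3ccccc32)cc1`: 16300 nM
- compound 3 `O=C(O)CN1C(=O)/C(=C/c2nc3ccccc3n2Cc2ccccc2)SC1=S`: 22700 nM

Compound 1 has no number of its own: it stands at the limit of > 50000 nM in this assay, at which 1 of the 3 values shown sits.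

Next in the series is compound 4 `O=C(O)CN1C(=O)/C(=C/c2nc3ccccc3n2Cc2ccc(C(F)(F)F)cc2)SC1=S`, not yet measured in this assay. The change is 4-(trifluoromethyl)phenyl in place of 4-bromo-2-fluorophenyl on a saturated chain carbon bound to an aromatic nitrogen. In words, 4-(trifluoromethyl)phenyl takes the place of 4-bromo-2-fluorophenyl on a saturated chain carbon bound to an aromatic nitrogen.

Two measured steps change this same place. With 4-cyanophenyl entering, the result is an at least 3.0-fold lower number from compound 1 to compound 2 (0.48 log units; beyond the scatter). With phenyl entering, the result is an at least 2.2-fold lower number from compound 1 to compound 3 (0.34 log units; beyond the scatter). Both lie beyond the scatter, and both are at least modest. Hydrogen in place of cyano gives a 1.4-fold higher number from compound 2 to compound 3 (0.14 log units; within the scatter), which stays within the scatter, so these two replacements give one common level.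

A step of similar size, toward a lower number, is therefore expected for compound 4, with compound 2 at 16300 nM and compound 3 at 22700 nM as the guide. Among the compounds with values here, no measured compound carries trifluoromethyl, so the range is kept wide, and a report of only a limit remains possible.

The expected step is an at least 2.0-fold lower number from compound 1 to compound 4 (0.30 log units; that floor lies within the scatter).

For compound 4 the estimated value is 25000 nM, with an expected range of 13000 nM to 50000 nM.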

Compound 4, half-maximal inhibitory concentration: 21400 nM
Beside the measured number, compound 4's estimate is 1.2-fold (0.07 log units) above it, within the range that was stated.
By their numbers in this assay, from the lowest: compounds 2, 4 and 3 (each within the scatter of the next). At a limit, above all of these: compound 1.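

On this aromatic carbon, hydrogen, cyano and trifluoromethyl sit at one common level in this assay: a 1.1-fold lower number from compound 3 to compound 4 (0.03 log units; within the scatter), and a 1.3-fold higher number from compound 2 to compound 4 (0.12 log units; within the scatter). Replacing 4-bromo-2-fluorophenyl with 4-(trifluoromethyl)phenyl gives an at least 2.3-fold lower number from compound 1 to compound 4 (0.36 log units; beyond the scatter), so a third group at this place departs from compound 1 in the same direction, and among the four compounds only compound 1 stands apart from the common level. Compound 1 is held at a limit and not at a number, so every step from it is a floor on the true size: the limit of > 50000 nM in this assay, at which 1 of the 4 values shown sits.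

Compound 1 differs from the others in both its bromine and its fluorine, so the compounds shown do not tell which of the two goes with its separate standing, and 4-bromophenyl and 2-fluorophenyl at the same place would divide the question. Also open, on these data alone, is whether the common level holds for a group of another kind on this aromatic carbon, such as an amine or a methoxy group, or whether it gives way when the saturated chain carbon bound to the aromatic nitrogen is replaced by a longer chain.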